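Hydrogen for hydroxy on compound 3

The compounds below may be only part of what the source reports. "The series", "measured", "known", "first", "only" and "open" are said of these compounds alone.

In a functional assay on HT-29 cells (Homo sapiens) for cytotoxicity, read by MTT assay, with a stated time of 24 h (a lower number here means a stronger inhibitor, a higher number a weaker inhibitor), compound 3 `C/C=C(\C)C(=O)C[C@@H]1[C@@]2(C)[C@@H](O)CCC(C)(C)[C@]2(O)CC[C@@]1(C)O` gives > 10000 nM, which is a limit and not a number. Compound 1 `C[C@@H]1O[C@@]1(C)C(=O)C[C@H]1[C@](C)(O)CC[C@@]2(O)C(C)(C)CCC[C@]12C` gives > 10000 nM, also a limit. Compound 2 `C[C@H]1O[C@]1(C)C(=O)C[C@H]1[C@](C)(O)CC[C@@]2(O)C(C)(C)CCC[C@]12C` gives > 10000 nM, again a limit. The series therefore shows (the limit of > 10000 nM in this assay, at which 3 of the 3 values shown sit).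

Compound 4 `C/C=C(\C)C(=O)C[C@H]1[C@](C)(O)CC[C@@]2(O)C(C)(C)CCC[C@]12C` differs from compound 3 by hydrogen in place of hydroxy on a saturated ring carbon. Among the measured compounds shown here, the only measured step is a step that the two limits leave unreadable from compound 1 to compound 2. It rests on (the fact that compounds 1 and 2 differ only in the configuration as drawn), so it offers no size to carry over to this change.

Compound 3 remains at > 10000 nM, a limit, so no clear direction can be expected in this assay, and another limit is the likeliest result. The expected step is a step that the limit leaves unreadable from compound 3 to compound 4. For compound 4 the estimate is 20000 nM, within an expected range of 5000 nM to 60000 nM.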

Compound 4, half-maximal inhibitory concentration: > 10000 nM
Compound 4: only a limit was reported; the forecaster's own chance of this, stated with the estimate: 70%; the middle value is on the limit's open side.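

With compound 4 at a limit, like compounds 1, 2 and 3, no step among these four compounds can be read in this assay. The compounds shown leave open whether hydroxy or hydrogen on that ring carbon changes cytotoxicity at all.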